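The compounds below may be only part of what the source reports. "The series", "measured", "known", "first", "only" and "open" are said of these compounds alone.

Compounds measured so far:
- compound 1, `c1cc2c(s1)CCOC21CCNCC1`: "not determined" (no result reported)
- compound 2, `CC(C)(C)c1ccc(CN2CCC3(CC2)OCCc2sccc23)cc1`: > 30 mL/min/g

In an ADME assay on microsomes from liver (Mus musculus) for metabolic stability, read by LC-MS, using NADPH, with a stated time of 30 min, tested at 0.5 uM (on this read-out lower numbers stand for slow clearance and higher numbers for fast clearance), compound 1 has no result, so there is no number on which compound 1 stands. Compound 2 in this assay reaches only a limit of the assay, (the limit of > 30 mL/min/g in this assay, at which 1 of the 2 values shown sits). No step between two measured compounds exists here, so the size of a change from the unsubstituted core cannot be read from the numbers shown. Compound 3, `Cc1ccc(CN2CCC3(CC2)OCCc2sccc23)[nH]1`, is the unmeasured member: (5-methyl-1H-pyrrol-2-yl)methyl in place of hydrogen on an amine nitrogen in a ring. From the compounds shown here alone, with nothing measured for compound 1 and only a limit for compound 2, the size and direction of this step in this assay stay open; the working expectation is a value toward the fast end, since compound 2 sits at the limit of > 30 mL/min/g in this assay, at which 1 of the 2 values shown sits. Compound 3 is expected to give about 25 mL/min/g, within 8 mL/min/g to 30 mL/min/g, and the measurement may again return only a limit.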

Compound 3, intrinsic clearance in a liver preparation (reported as CLH), per the amount of preparation that the assay uses: 28.7 mL/min/g
Compound 3: middle estimate off by 1.1-fold (0.06 log units), on the low side, within the range that was stated.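

No new step can be read in this assay from compound 3, as compound 1 has no number there and compound 2 gives only a limit. The compounds shown leave open how far (5-methyl-1H-pyrrol-2-yl)methyl on the amine nitrogen shifts clearance relative to the core of compound 1.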